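The compounds below may be only part of what the source reports. "The series", "measured", "known", "first", "only" and "open" are said of these compounds alone.

Of the compounds shown here, two have been measured in an assay on isolated protein for inhibition of G protein-coupled receptor kinase 5 (Homo sapiens), read by TR-FRET, with stated times of 10 min and 1 h; on this read-out higher numbers stand for weaker inhibition and lower numbers for stronger inhibition. Compound 1, with the structure `Nc1ncc(-c2cnn(C3CCNCC3)c2)cc1-c1nc2ccc(Nc3cc(C(F)(F)F)cc(C(F)(F)F)c3)cc2o1`, carries a 3,5-bis(trifluoromethyl)anilino group on the shared core, and in this assay compound 1 gives 4200 nM. Compound 2, with the structure `Nc1ncc(-c2cnn(C3CCNCC3)c2)cc1-c1nc2ccc(-c3cn[nH]c3)cc2o1`, carries a 1H-pyrazol-4-yl group at the same position, and in this assay compound 2 gives 1780 nM. Of the two numbers, that of compound 2 is the lower one, and the gap to compound 1 lies beyond the scatter of repeated measurements, so compound 2 stands as the stronger inhibitor of the pair.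

Compound 3, with the structure `Nc1ncc(-c2cnn(C3CCNCC3)c2)cc1-c1nc2ccc(NC(=O)Nc3ccccc3)cc2o1`, has not been measured. It differs from compound 2 in one place: (phenylcarbamoyl)amino in place of 1H-pyrazol-4-yl on an aromatic carbon. Going by the values given here, no measured pair shows a change of this kind, so nothing comparable can be drawn upon. Because compound 2 sits at 1780 nM and the change is a single swap on the same aromatic carbon, a modest step in either direction is expected, and the expected step of a 1.1-fold higher number from compound 2 to compound 3 (0.05 log units; within the scatter) is small. Compound 3 is estimated to give about 2000 nM, with a likely range from 500 nM to 8000 nM.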

Compound 3, half-maximal inhibitory concentration: 1660 nM
Beside the measured number, compound 3's estimate is 1.2-fold (0.08 log units) above it, and the stated range covers the measured number.
By their numbers in this assay, from the lowest: compounds 3 and 2 (each within the scatter of the next); then compound 1.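

In this assay, the step of a 1.1-fold lower number from compound 2 to compound 3 (0.03 log units; within the scatter) shows that this aromatic carbon can carry two very different groups with no difference that can be told from the scatter. The 1H-pyrazol-4-yl group has 5 heavy atoms and a five-membered aromatic ring, whereas the (phenylcarbamoyl)amino group has 10 heavy atoms, a six-membered aromatic ring of carbon only and a double bond outside the aromatic rings, so at this position neither the larger size nor the change of ring shifts the read-out in this pair. Nothing measured alongside these numbers explains why the two groups read alike. The compounds shown leave open how much smaller groups at this aromatic carbon, such as a methyl or a plain amine, would read, and what a carboxylic acid would do there. They also leave open whether the phenyl ring of the (phenylcarbamoyl)amino group matters at all, which a chlorine or a methoxy on that ring, or an acetamide in place of the whole group, could begin to test.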